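The source may report more compounds than this note shows. Statements on the series, on what has been measured and on what is new or still open speak of the compounds shown alone.

Within the data shown here, in a functional assay on the whole organism (strain Holtzmann) for inhibition, with Rattus norvegicus as the target, at a dose of 50 mg/kg by the oral route (a higher number here means more inhibition at the dose given (going by the name of the read-out), a lower number less inhibition), compound 2 `O=C(O)c1ccccc1S(=O)(=O)c1cccc(C(F)(F)F)c1` gives 23%, the second highest of the three numbers measured so far. Nearest to it is compound 3 `Cc1cccc(Sc2ccccc2C(=O)O)c1C`, which gives 26%, a reading within the usual scatter of that of compound 2, so the two cannot be ordered. Furthest from it is compound 1 `Cc1cccc([S+]([O-])c2ccccc2C(=O)O)c1C`, which gives 0%, a gap that lies beyond the scatter. Compound 4 `O=C(O)c1ccccc1S(=O)(=O)c1ccccc1` has not yet been measured. It differs from compound 2 in one place: hydrogen in place of trifluoromethyl on an aromatic carbon. Among the measured compounds shown here, no pair of measured compounds isolates this change, so nothing is known of its effect. In this assay a small downward step is expected, a number 8 percentage points lower from compound 2 to compound 4 (within the scatter), possibly none beyond the scatter. Compound 4 is therefore estimated at 15%, with a range from 0% to 35%.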

Compound 4, a percentage reported as inhibition, in the whole organism at one dose (the size of the read-out at that dose, not a potency): 0%
The estimate for compound 4 lay 15 percentage points above the measured number, and the stated range covers the measured number.
By their numbers in this assay, from the lowest: compounds 1 and 4 (each within the scatter of the next); then compounds 2 and 3 (each within the scatter of the next).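

In this assay, hydrogen in place of trifluoromethyl on this aromatic carbon, meta to a large group, gives a number 23 percentage points lower from compound 2 to compound 4 (beyond the scatter), the first single change that can be read among these compounds. At this position, then, the trifluoromethyl of compound 2 goes with a level of inhibition that compound 4, with hydrogen there, does not reach at this dose. Nothing available explains this step. On these data alone, whether chlorine or a methoxy group at this position would keep the reading of compound 2 stays open. So does whether the same change would give a similar step on the core of compound 3.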